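Opening the Ring: Pentyl for Cyclopentyl on the Amine

The compounds below may be only part of what the source reports. "The series", "measured", "known", "first", "only" and "open" are said of these compounds alone.

Three measured compounds share one core and differ only in the group on the amine nitrogen in the ring. Compound 1 `COc1cc(N)c(Cl)cc1NC(=O)C1CCN(C2CCCC2)CC1` carries a cyclopentyl there. In a functional assay on the whole organism for antagonist activity, with Mus musculus as the target (a higher number here means that more compound is needed for the effect, a lower number that less compound is needed), compound 1 gives > 10 mg/kg, which is a limit of the assay and not a number. Compound 2 `COc1cc(N)c(Cl)cc1NC(=O)C1CCN(CC2CCC2)CC1` gives > 10 mg/kg in this assay, again only a limit. Compound 3 `COc1cc(N)c(Cl)cc1NC(=O)C1CCN(Cc2ccc([N+](=O)[O-])cc2)CC1` gives > 4 mg/kg in this assay, also a limit. The step that the two limits leave unreadable from compound 1 to compound 2 and the step that the two limits leave unreadable from compound 2 to compound 3 therefore carry no readable size, because two of the values sit at the limit of > 10 mg/kg in this assay, at which 2 of the 3 values shown sit, and one at the limit of > 4 mg/kg in this assay, at which 1 of the 3 values shown sits.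

Compound 4 `CCCCCN1CCC(C(=O)Nc2cc(Cl)c(N)cc2OC)CC1` arises from compound 1 by the change (pentyl in place of cyclopentyl on an amine nitrogen in a ring). Going by the values given here, no measured step bears on this change with a readable size, so neither direction can be drawn from the measured pairs; all that is known is that compound 1 sits at a limit. Compound 4 is expected to give about 15 mg/kg, with a range from 4 mg/kg to 40 mg/kg. The expected step that the limit leaves unreadable from compound 1 to compound 4 is thus estimated to stay within the scatter, and a further limit rather than a number is the likeliest outcome.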

Compound 4, dose for half-maximal effect: > 10 mg/kg
Compound 4 was reported as a limit (the forecaster's own chance of this, stated with the estimate: 70%); the middle value is on the limit's open side.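

Compound 4 gives > 10 mg/kg in this assay, which is a limit of the assay and not a number. The steps from compound 1, compound 2 and compound 3 to compound 4 cannot be read, because each pair has only limits: the limit of > 10 mg/kg in this assay, at which 3 of the 4 values shown sit. The compounds shown leave open whether pentyl and cyclopentyl differ at all on the amine nitrogen.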